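A few compounds are considered here, and "the series" means these few. Any claim that something is new, unique, unknown or untested is made for them only; others in the source may bear on it.

Compound 1 `COc1ccc2c(OCc3nnc4sc(-c5cc[nH]c5)nn34)ccnc2c1` gives 353 nM in a functional assay on EBC-1 cells (Homo sapiens) for antiproliferative activity, with a stated time of 72 h; a lower number here means a stronger inhibitor, a higher number a weaker inhibitor; compound 2 `COc1ccc2c(OCc3nnc4sc(-c5cnn(C)c5)nn34)ccnc2c1` gives 88 nM in this assay; compound 3 `COc1ccc2c(OCc3nnc4sc(-c5cc6cc(F)ccc6[nH]5)nn34)ccnc2c1` gives "not determined" (no result reported) in this assay.

Compound 3 therefore stands nowhere on the numbers: no value for it is known, and only compounds 1 and 2 anchor the series. Compound 4 `COc1ccc(-c2nn3c(COc4ccnc5cc(OC)ccc45)nnc3s2)cc1` differs from compound 3 by 4-methoxyphenyl in place of 5-fluoro-1H-indol-2-yl on an aromatic carbon. For the measured compounds named here, the one measured step, a 4.0-fold lower number from compound 1 to compound 2 (0.60 log units; beyond the scatter), concerns the same position and shows that exchanging the group there can move the number beyond the scatter. That step does not involve either of the groups exchanged here, so it sets only a rough size. Compound 4 is expected to fall near the two measured values, at an estimated 160 nM, between 35 nM and 800 nM.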

Compound 4, half-maximal inhibitory concentration: 161 nM
Estimate against measurement, compound 4: 1.0-fold (0.00 log units) below; measured number inside the range.
By their numbers in this assay, from the lowest: compounds 2 and 4 (each within the scatter of the next); then compound 1.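

In this assay, the position on the shared core also accepts 4-methoxyphenyl, with its six-membered aromatic ring of carbon only: the change from 1-methyl-1H-pyrazol-4-yl gives a 1.8-fold higher number from compound 2 to compound 4 (0.26 log units; within the scatter). The change from 1H-pyrrol-3-yl gives a 2.2-fold lower number from compound 1 to compound 4 (0.34 log units; beyond the scatter), so compound 1 now has the highest number of the three, apart from both others. Nothing measured here explains these differences. As far as these compounds go, how an amine or a carboxylic acid on the 4-methoxyphenyl ring would shift the number remains open.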